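The source may hold more compounds than are shown below. What is called first, only, known or untested is meant among the compounds shown, and "the series" means these compounds.

Measured in a functional assay on HeLa cells (Homo sapiens) for antiproliferative activity, read by MTT assay, with a stated time of 48 h; on this read-out lower numbers stand for stronger inhibition and higher numbers for weaker inhibition:
- compound 1 `COc1ccc(C(=O)c2ccc(OC)c3c2OC(C)(C)C=C3)c(NC(=O)CBr)c1`: 2140 nM
- compound 2 `COc1ccc(C(=O)c2ccc(OC)c3c2OC(C)(C)C=C3)c(NC(=O)CN)c1`: 410 nM
- compound 3 `COc1ccc(C(=O)c2ccc3c(c2)C=CC(C)(C)O3)c(NC(=O)CN)c1`: 580 nM

Compound 2 stands at the low end of these numbers, and compound 3 lies within the scatter of it. Compound 1 lies beyond the scatter, as shown by a 5.2-fold lower number from compound 1 to compound 2 (0.72 log units; beyond the scatter).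

Next in the series is compound 4 `CCNCC(=O)Nc1cc(OC)ccc1C(=O)c1ccc(OC)c2c1OC(C)(C)C=C2`. Its difference from compound 2 is ethyl in place of hydrogen on an amine nitrogen.

Going by the values given here, only one measured step bears on this change: a 5.2-fold lower number from compound 1 to compound 2 (0.72 log units; beyond the scatter). Among the compounds with values here, that modest step installed the amino group but does not test substitution on its nitrogen, so no measured step shows the effect of ethyl here. On these data alone, the direction remains open, and no step beyond the scatter is expected in this assay. The expected change is a 1.2-fold higher number from compound 2 to compound 4 (0.09 log units; within the scatter). For compound 4 the estimated value is 500 nM, with an expected range of 200 nM to 1300 nM.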

Compound 4, half-maximal inhibitory concentration: 2690 nM
Compound 4: middle estimate off by 5.4-fold (0.73 log units), on the low side, outside the stated range (above it).
By their numbers in this assay, from the lowest: compounds 2 and 3 (each within the scatter of the next); then compounds 1 and 4 (each within the scatter of the next).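

In this assay, the amine nitrogen on the side chain does not tolerate every substitution: ethyl in place of hydrogen gives a 6.6-fold higher number from compound 2 to compound 4 (0.82 log units; beyond the scatter) and so removes the advantage held by the free amino group. Ethylamino in place of bromo gives a 1.3-fold higher number from compound 1 to compound 4 (0.10 log units; within the scatter) and so shows no gain over the bromo compound, which means that the improvement seen with amino does not extend to ethylamino. Nothing at hand accounts for this loss.

On these data alone, it remains open whether the loss is specific to ethyl or extends to other groups on this nitrogen, such as methyl, a longer propyl chain, or a second substituent as in dimethylamino. Also open, as far as these compounds go, is whether ethyl has the same effect on the core of compound 3.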